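The compounds below may be only part of what the source reports. "The series", "measured", "known", "first", "only" and "open" are said of these compounds alone.

Of the compounds shown here, three built on one shared core have been tested in a functional assay on HOP-62 cells (Homo sapiens) for antiproliferative activity, with a stated time of 48 h; on this read-out lower numbers stand for stronger inhibition of growth and higher numbers for weaker inhibition of growth. Compound 1 `Cc1cc(O)c(C2=NN(c3ccc(S(N)(=O)=O)cc3)C(c3ccccc3O)C2)cc1Cl` gives 4500 nM, compound 2 `Cc1cc(O)c(C2=NN(c3ccc(S(N)(=O)=O)cc3)C(c3ccccc3Cl)C2)cc1Cl` gives 4160 nM, and compound 3 `COc1ccc(C2CC(c3cc(Cl)c(C)cc3O)=NN2c2ccc(S(N)(=O)=O)cc2)cc1OC` gives 14100 nM, the highest of the three. The steps into compound 3 were a 3.1-fold higher number from compound 1 to compound 3 (0.50 log units; beyond the scatter) and a 3.4-fold higher number from compound 2 to compound 3 (0.53 log units; beyond the scatter), whereas a 1.1-fold lower number from compound 1 to compound 2 (0.03 log units; within the scatter). Compound 4 `COc1ccc(C2CC(c3cc(Cl)c(C)cc3O)=NN2c2ccc(S(N)(=O)=O)cc2)c(OC)c1OC` differs from compound 3 by methoxy in place of hydrogen on an aromatic carbon. Within the data shown here, no measured step adds a methoxy group, so the two steps that altered the 3,4-dimethoxyphenyl side of the core only show that changes there shifted the number modestly. A step of at most similar size, in either direction, is expected, and the estimate for compound 4 is 14000 nM, ranging from 6000 nM to 33000 nM, which means a 1.0-fold lower number from compound 3 to compound 4 (0.00 log units; within the scatter) is expected.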

Compound 4, concentration for total growth inhibition: 4560 nM
The estimate for compound 4 lay 3.1-fold (0.49 log units) above the measured number; the whole stated range lies above it.
By their numbers in this assay, from the lowest: compounds 2, 1 and 4 (each within the scatter of the next); then compound 3.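

In this assay, methoxy in place of hydrogen, ortho to a large group and ortho to a methoxy group, turns 3,4-dimethoxyphenyl into 2,3,4-trimethoxyphenyl and gives a 3.1-fold lower number from compound 3 to compound 4 (0.49 log units; beyond the scatter), so this ring position does affect the number. With a 1.1-fold higher number from compound 2 to compound 4 (0.04 log units; within the scatter) and a 1.0-fold higher number from compound 1 to compound 4 (0.01 log units; within the scatter), the 2,3,4-trimethoxyphenyl compound cannot be told apart from the 2-chlorophenyl and 2-hydroxyphenyl compounds. Nothing given here explains the change. As far as these compounds go, whether an ethoxy group or an amine at this position would shift the number in the same way remains open.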